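Chloro for Fluoro on a Second Triazole Core

The source may report more compounds than this note shows. Statements on the series, on what has been measured and on what is new or still open speak of the compounds shown alone.

Compound 1 `CC[C@H](CCn1cncn1)c1ccc(F)cc1` and compound 2 `CC[C@H](CCn1cncn1)c1ccc(Cl)cc1` share one core and differ in a single place, (chloro in place of fluoro on an aromatic carbon). In an ADME assay on HEp-2 cells (Homo sapiens) for cytotoxicity, read by MTT assay, with a stated time of 3 days (a higher number here means that more compound is tolerated, a lower number that less compound is tolerated), compound 1 gives 103 ug/mL and compound 2 gives 50.6 ug/mL; that step is a 2.0-fold lower number from compound 1 to compound 2 (0.31 log units; beyond the scatter). Compound 3 `CCC[C@@H](CCn1cncn1)c1ccc(F)cc1` carries a different core; the difference between the two cores of compound 1 and compound 3 is not broken down here. In this assay compound 3 gives 55.3 ug/mL, a number that lies within the scatter of both compound 1 and compound 2, so no order among the three can be drawn from it. Compound 4 `CCC[C@@H](CCn1cncn1)c1ccc(Cl)cc1` has not yet been measured and differs from compound 3 by the same change as before, (chloro in place of fluoro on an aromatic carbon). For the measured compounds named here, because the first pair showed a 2.0-fold lower number from compound 1 to compound 2 (0.31 log units; beyond the scatter), a step of similar size is expected for the second pair, a 1.9-fold lower number from compound 3 to compound 4 (0.28 log units; within the scatter), with the single earlier example as its only support. For compound 4 in this assay the expected number is 29 ug/mL, with a likely range from 15 ug/mL to 58 ug/mL.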

Compound 4, half-maximal cytotoxic concentration: 36.6 ug/mL
For compound 4 the middle estimate is 1.3-fold (0.10 log units) below the measured one; low and high end bracket the measured number.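

On the core of compound 3, the exchange of fluoro for chloro gives a 1.5-fold lower number from compound 3 to compound 4 (0.18 log units; within the scatter) in this assay, and this step alone does not stand clear of the scatter. Set beside the earlier step, it gives no sign that the change behaves differently on the two cores, so the two results are compatible with one step carried from one core to the other: the same change on two cores in this assay, a 2.0-fold lower number (0.31 log units; beyond the scatter) from compound 1 to compound 2 and a 1.5-fold lower number (0.18 log units; within the scatter) from compound 3 to compound 4, 1.3-fold (0.13 log units) apart, within the scatter of two such steps. This agreement rests on just two pairs and two closely related cores, so it does not show that the step would hold on other cores in this series, and it gives no reason for the step.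

The compounds shown carry only fluoro or chloro on the aromatic ring, so it remains open whether a bromo or methoxy group in the same place would fit this picture. Also open, as far as these compounds go, is whether a longer chain on the core, or an amine or carboxylic acid elsewhere on it, would leave the step unchanged.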